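Piperidin-1-yl in place of diethylamino on the shared core

This account rests on a few compounds, and the source may have more. Where it says the series, first, only, none or still open, it means among the compounds named here.

In a functional assay on HeLa cells (Homo sapiens) for cytotoxicity, read by sulforhodamine B assay, with a stated time of 72 h (a higher number here means a weaker inhibitor, a lower number a stronger inhibitor), compound 1 (`C=C1C(=O)O[C@@H]2CC(C)=C([C@@H](C)CCCOC(C)=O)[C@@H](OC(=O)CCl)[C@H]12`) gives 28500 nM, compound 2 (`C=C1C(=O)O[C@@H]2CC(C)=C([C@@H](C)CCCOC(C)=O)[C@@H](OC(=O)CN(CC)CC)[C@H]12`) gives 10700 nM and compound 3 (`C=C1C(=O)O[C@@H]2CC(C)=C([C@@H](C)CCCOC(C)=O)[C@@H](OC(=O)CN3CCCC3)[C@H]12`) gives 12700 nM. Compound 2 thus stands at the low end of these numbers, level with compound 3 and clear of compound 1. Compound 4 (`C=C1C(=O)O[C@@H]2CC(C)=C([C@@H](C)CCCOC(C)=O)[C@@H](OC(=O)CN3CCCCC3)[C@H]12`) carries piperidin-1-yl in place of diethylamino on a saturated chain carbon bound to a carbonyl carbon. Going by the values given here, the closest precedent is the exchange of diethylamino for pyrrolidin-1-yl, a 1.2-fold higher number from compound 2 to compound 3 (0.07 log units; within the scatter), which stayed within the scatter. Replacing chloro gave larger, modest steps, a 2.7-fold lower number from compound 1 to compound 2 (0.43 log units; beyond the scatter) and a 2.2-fold lower number from compound 1 to compound 3 (0.35 log units; beyond the scatter), but compound 4 keeps an amine. The expected change is a 1.1-fold higher number from compound 2 to compound 4 (0.03 log units; within the scatter), none beyond the scatter. For compound 4 the estimate is 11500 nM, with an expected range of 6000 nM to 22000 nM.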

Compound 4, half-maximal inhibitory concentration: 10300 nM
The estimate for compound 4 lay 1.1-fold (0.05 log units) above the measured number; the measured number falls inside the stated range.
By their numbers in this assay, from the lowest: compounds 4, 2 and 3 (each within the scatter of the next); then compound 1.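

In this assay, piperidin-1-yl in place of diethylamino on this saturated chain carbon left the number within the scatter (a 1.0-fold lower number from compound 2 to compound 4 (0.02 log units; within the scatter)), as did piperidin-1-yl in place of pyrrolidin-1-yl (a 1.2-fold lower number from compound 3 to compound 4 (0.09 log units; within the scatter)), so these three amines stand level here, with or without a ring. Piperidin-1-yl in place of chloro gave a modest step (a 2.8-fold lower number from compound 1 to compound 4 (0.44 log units; beyond the scatter)), which shows the difference from chloro in all three amines. No available evidence explains this level result.

From the compounds shown here alone, whether a morpholine ring or a primary amine would stay at this level remains open. So does whether a hydroxyl in place of chloro would give a similar step without any amine.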